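This account rests on a few compounds, and the source may have more. Where it says the series, first, only, none or still open, it means among the compounds named here.

Compound 2 `COc1cc(/C=C2\CCC/C(=C\c3ccc([N+](=O)[O-])cc3)C2=O)cc(Br)c1O` is one of two compounds tested in a functional assay on MDA-MB-231 cells (Homo sapiens) for cytotoxicity, read by MTT assay; a higher number here means a weaker inhibitor, a lower number a stronger inhibitor. In this assay compound 2 gives only a limit of the assay, > 100 ug/mL, so no actual number is known for it. Compound 1 `COc1cc(/C=C2\CCC/C(=C\c3cccc([N+](=O)[O-])c3)C2=O)cc(Br)c1OC` in this assay gives 13.9 ug/mL. Among the measured compounds shown here, the only pointer among the numbers is the limit of > 100 ug/mL in this assay, at which 1 of the 2 values shown sits, which holds compound 2 and not compound 1. Compound 3 `COc1cc(/C=C2\CCC/C(=C\c3ccc([N+](=O)[O-])cc3)C2=O)cc(Br)c1OC` has not yet been measured; it differs from compound 2 by methyl in place of hydrogen on an oxygen on an aromatic ring, a change that read one bond further out is hydroxy to methoxy. Compound 1 likewise carries a methoxy rather than a hydroxy. For the measured compounds named here, because compound 2 sits at a limit, no measured step sets the size of this change. Compound 3 is expected to show an at least 5.0-fold lower number from compound 2 to compound 3 (0.69 log units; beyond the scatter) because compound 1 gives 13.9 ug/mL. Compound 3 is therefore estimated at 20 ug/mL, within 5 ug/mL to 90 ug/mL.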

Compound 3, half-maximal inhibitory concentration: 8.71 ug/mL
For compound 3 the middle estimate is 2.3-fold (0.36 log units) above the measured one, within the range that was stated.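

In this assay, among the compounds shown here, methyl in place of hydrogen on the aromatic oxygen, hydroxy to methoxy, gives an at least 11-fold lower number from compound 2 to compound 3 (1.05 log units; beyond the scatter), which is the first measured sign that this oxygen matters on the core carrying 4-nitrophenyl. As far as these compounds go, the true size of that step stays unknown because compound 2 stands at a limit of the assay: the limit of > 100 ug/mL in this assay, at which 1 of the 3 values shown sits. With methoxy in place, 4-nitrophenyl in place of 3-nitrophenyl gives a 1.6-fold lower number from compound 1 to compound 3 (0.20 log units; within the scatter), so in this assay the two nitrophenyl forms cannot be told apart.

From the compounds shown here alone, it remains open whether a larger group on this oxygen, such as ethoxy or a longer chain, would give a number like that of compound 3. Going by these compounds, it is also open how the hydroxy to methoxy step reads with 3-nitrophenyl, or with an amine in place of the nitro group.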